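Replacing methoxycarbonyl with hydroxy on compound 2

The compounds below may be only part of what the source reports. "The series", "measured", "known", "first", "only" and "open" are said of these compounds alone.

In a physicochemical assay for solubility, at pH 7.4 (a lower number here means a less soluble compound, a higher number a more soluble compound), compound 1 (`Cc1cc(NC(=O)Nc2cccc(F)c2)c2ccccc2n1`) gives 100 nM as its value. Compound 2 (`COC(=O)c1ccc(NC(=O)Nc2cc(C)nc3ccccc23)cc1`) gives 1200 nM as the higher of these two numbers, and the gap between them lies beyond the scatter. Compound 3 (`Cc1cc(NC(=O)Nc2ccc(O)cc2)c2ccccc2n1`) has not yet been measured. It differs from compound 2 by hydroxy in place of methoxycarbonyl on an aromatic carbon, para to a large group (hydroxy in place of methoxycarbonyl on an aromatic carbon). Among the compounds with values here, no measured pair shows this change, so the two values offer a range but no direction. No step beyond the scatter is therefore expected in this assay, and any drift is expected to be slightly downward. An estimated 1.5-fold lower number from compound 2 to compound 3 (0.18 log units; within the scatter) is what this expectation amounts to. In this assay compound 3 is estimated at 800 nM with an expected range from 200 nM to 3000 nM for the coming measurement.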

Compound 3, solubility: 100 nM
Compound 3: middle estimate off by 8.0-fold (0.90 log units), on the high side; the whole stated range lies above it.
By their numbers in this assay, from the lowest: compounds 1 and 3 (each within the scatter of the next); then compound 2.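

In this assay, putting hydroxy in place of methoxycarbonyl on this aromatic carbon, para to a large group, gives a 12-fold lower number from compound 2 to compound 3 (1.08 log units; beyond the scatter), the first measured sign that the group at this position matters to the read-out. With hydroxy in this place, the higher value of compound 2 is not kept, and 4-hydroxyphenyl in place of 3-fluorophenyl on the amide-type nitrogen gives no change at the digits printed from compound 1 to compound 3 (within the scatter), so the two groups cannot be told apart here. No measurement shown accounts for the large step.

A single pair cannot show whether the higher value of compound 2 belongs to methoxycarbonyl specifically or would also appear with other groups at this position. As far as these compounds go, how a carboxylic acid or an amine on the same carbon would compare remains open.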